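Taking the Methoxy Group Off Compound 1

A few compounds are considered here, and "the series" means these few. Any claim that something is new, unique, unknown or untested is made for them only; others in the source may bear on it.

Of the compounds shown here, three sharing one core have been tested in an assay on isolated protein for inhibition of alpha-mannosidase (Canavalia ensiformis), tested at 1000 uM; on this read-out higher numbers stand for more inhibition at the one concentration tested (going by the name of the read-out) and lower numbers for less inhibition. Compound 1 `COc1cccc([C@]2(CO)NC[C@@H](O)[C@@H]2O)c1` gives 0%. Compound 2 `COc1ccc([C@]2(CO)NC[C@@H](O)[C@@H]2O)cc1OC` gives 0%, and compound 3 `OC[C@]1(c2ccc(O)cc2)NC[C@H](O)[C@H]1O` gives 3.4%. Compound 1 thus stands level with compound 2, the two of them together the lowest of the three numbers, while compound 3 sits only a few points higher, a gap that lies within the scatter of this kind of measurement.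

Compound 4 `OC[C@@]1(c2ccccc2)NC[C@@H](O)[C@@H]1O` has not been measured yet. It differs from compound 1 in one place: hydrogen in place of methoxy on an aromatic carbon.

One measured step speaks to this change, the one going the opposite way by adding a methoxy group: no change at the digits printed from compound 1 to compound 2 (within the scatter). Since adding methoxy left the number where it was, taking methoxy away is not expected to move it either, and the step of no change at the digits printed from compound 1 to compound 4 (within the scatter) is expected to stay within the scatter. Compound 4 is therefore expected to give 0% in this assay, most likely between 0% and 8%.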

Compound 4, a percentage reported as inhibition, at one concentration (the size of the read-out at that concentration, not a potency): 0%
Estimate against measurement, compound 4: no gap at the digits printed; the range from low to high includes it.
By their numbers in this assay, from the lowest: compounds 1, 2, 4 and 3 (each within the scatter of the next).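

Taking the methoxy group off gives no change at the digits printed from compound 1 to compound 4 (within the scatter) in this assay. Among the compounds shown here, this is the first reading of a change on this aromatic carbon itself, whereas the earlier step added a second methoxy group on a different carbon of the ring. Compound 1 stands at 0% on this read-out, so the step could only have shown a rise, and neither methoxy nor hydrogen at this place lifts the number clear of the scatter. No measurement offers an explanation for this result.

The compounds shown leave open whether an amine or a carboxylic acid on this same carbon would move the number beyond the scatter. With only methoxy and hydrogen compared here, they also leave open whether any group at this place matters at all.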